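Piperazin-1-yl in place of vinyl on a carbonyl carbon

The source may report more compounds than this note shows. Statements on the series, on what has been measured and on what is new or still open speak of the compounds shown alone.

Compound 1 `CCCS(=O)(=O)Nc1ccc(-c2cc(=O)c3c(O)cc(OC)c(OC(C)C)c3o2)cc1`: 76900 nM
Compound 2 `C=CC(=O)Nc1ccc(-c2cc(=O)c3c(O)cc(OC)c(OC(C)C)c3o2)cc1`: 14700 nM

In a functional assay on DU-145 cells (Homo sapiens) for antiproliferative activity, read by MTT assay, with a stated time of 3 days (on this read-out higher numbers stand for weaker inhibition and lower numbers for stronger inhibition), compound 2 gives the lower of the two numbers, 14700 nM, while compound 1 gives 76900 nM. Among the measured compounds shown here, the only measured step, a 5.2-fold lower number from compound 1 to compound 2 (0.72 log units; beyond the scatter), puts vinylcarbonyl in place of propylsulfonyl on a nitrogen on an aromatic ring. Compound 3 `COc1cc(O)c2c(=O)cc(-c3ccc(NC(=O)N4CCNCC4)cc3)oc2c1OC(C)C` keeps that carbonyl and changes what it carries: piperazin-1-yl in place of vinyl on a carbonyl carbon. Piperazin-1-yl thus stands in place of vinyl on a carbonyl carbon, which turns vinylcarbonyl into (piperazin-1-yl)carbonyl.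

The measured step bears on this only loosely. It shows that a change on the same nitrogen can move the number in this assay beyond the scatter, yet neither of its compounds carries piperazin-1-yl. For the measured compounds named here, no measured pair shows this exchange, so the data give no direction. The central expectation is therefore no shift beyond the scatter, with a wide margin on both sides. The expected step is a 1.2-fold lower number from compound 2 to compound 3 (0.09 log units; within the scatter). The estimated value for compound 3 is 12000 nM, with an expected range from 3000 nM to 50000 nM.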

Compound 3, half-maximal inhibitory concentration: 8000 nM
Estimate against measurement, compound 3: 1.5-fold (0.18 log units) above; low and high end bracket the measured number.
By their numbers in this assay, from the lowest: compounds 3 and 2 (each within the scatter of the next); then compound 1.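

In this assay, the step of a 1.8-fold lower number from compound 2 to compound 3 (0.26 log units; within the scatter) shows that the carbonyl carbon on this amide-type nitrogen can carry piperazin-1-yl, a six-membered non-aromatic ring, in place of vinyl without a shift beyond the scatter, so compound 2 and compound 3 cannot be told apart here. The step of a 9.6-fold lower number from compound 1 to compound 3 (0.98 log units; beyond the scatter) is beyond the scatter, and it puts a second carbonyl-bearing compound on the lower side of the propylsulfonyl compound, so among these three compounds both groups attached through a carbonyl give lower numbers than propylsulfonyl, with compound 1 the only sulfonyl example. No evidence is available here that accounts for these numbers.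

The compounds shown leave open whether the ring of piperazin-1-yl matters at all on this carbonyl carbon, since an open-chain dimethylamino group or a morpholine ring in the same place would separate the ring from its second nitrogen. They also leave open whether a shorter sulfonyl group such as methylsulfonyl on the same nitrogen would stay with compound 1 or come closer to compound 2 and compound 3.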